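The source may hold more compounds than are shown below. What is called first, only, known or untested is meant among the compounds shown, and "the series" means these compounds.

In a functional assay on HMEC-1 cells (Homo sapiens) for antiproliferative activity, read by cell counting, with a stated time of 7 days; a lower number here means a stronger inhibitor, a higher number a weaker inhibitor:
- Compound 1 `CCOC(=O)CN(Cc1cc(F)cc(F)c1)c1ccc2c(c1)OC(C)(COc1ccc(C#N)cc1)CN2C`: 49000 nM
- Compound 2 `CCOC(=O)C(=O)N(Cc1ccccc1)c1ccc2c(c1)OC(C)(CO)CN2C`: > 100000 nM

For compound 2, the reading of > 100000 nM is a limit of the assay, not a number. Compound 3 `CCOC(=O)C(=O)N(Cc1cc(F)cc(F)c1)c1ccc2c(c1)OC(C)(CO)CN2C` differs from it in one place: 3,5-difluorophenyl in place of phenyl on a saturated chain carbon bound to an amide-type nitrogen. This puts 3,5-difluorophenyl in place of phenyl on a saturated chain carbon bound to an amide-type nitrogen. Compound 1 carries the same 3,5-difluorobenzyl group on a core with other differences, and compound 1 gives 49000 nM. A small move toward stronger inhibition in this assay is therefore expected, an estimated at least 1.1-fold lower number from compound 2 to compound 3 (0.04 log units; that floor lies within the scatter). For compound 3 the estimated value is 90000 nM, with an expected range of 35000 nM to 200000 nM.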

Compound 3, half-maximal inhibitory concentration: 89000 nM
Compound 3: the middle estimate sits 1.0-fold (0.00 log units) above what was measured, and the stated range covers the measured number.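

In this assay compound 3 gives 89000 nM, so 3,5-difluorophenyl at this place on the saturated chain carbon yields a value on the scale. Going by these compounds, compound 2 stands only at a limit of the assay, not a number: the limit of > 100000 nM in this assay, at which 1 of the 3 values shown sits. The change can therefore be read only as a floor, an at least 1.1-fold lower number from compound 2 to compound 3 (0.05 log units; that floor lies within the scatter), and its true size remains unknown.

On these data alone, it remains open how a pyridylmethyl group or a phenethyl chain would read at this place. Also open, as far as these compounds go, is how a carboxylic acid in place of the ethyl ester would read.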